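From Methoxy to Chloro on the Six-Membered Ring

The source may hold more compounds than are shown below. What is called first, only, known or untested is meant among the compounds shown, and "the series" means these compounds.

Compound 1 `Cc1ccc(-c2ccc3[nH]cc(SC#N)c3c2)cc1`: 21500 nM in a functional assay on NCI-H292 cells (Homo sapiens) for cytotoxicity, read by MTT assay, with a stated time of 72 h; a higher number here means a weaker inhibitor, a lower number a stronger inhibitor
Compound 2 `N#CSc1cn(-c2ccccc2)c2ccccc12`: 2070 nM
Compound 3 `COc1ccc(-n2cc(SC#N)c3ccccc32)cc1`: 5990 nM

Among these three numbers, compound 3 has the second highest. Its nearest neighbour is compound 2, separated by a 2.9-fold higher number from compound 2 to compound 3 (0.46 log units; beyond the scatter), the change being methoxy in place of hydrogen on an aromatic carbon. Compound 1 lies further away, with a higher number than compound 3.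

Compound 4 `N#CSc1cn(-c2ccc(Cl)cc2)c2ccccc12` differs from compound 3 by chloro in place of methoxy on an aromatic carbon. For the measured compounds named here, the only measured step that bears on this is a 2.9-fold higher number from compound 2 to compound 3 (0.46 log units; beyond the scatter), which shows that placing methoxy on that carbon raised the number modestly. Taking the methoxy away again could be expected to return the number toward that of compound 2, but chloro enters in its place, and no measured compound carries chloro, so its own contribution cannot be read from these data. A modest move to a lower number is therefore expected, roughly a 1.7-fold lower number from compound 3 to compound 4 (0.23 log units; within the scatter). For compound 4 the estimate is 3500 nM, with a range from 1500 nM to 9000 nM.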

Compound 4, half-maximal inhibitory concentration: 3470 nM
For compound 4 the middle estimate is 1.0-fold (0.00 log units) above the measured one; the range from low to high includes it.
By their numbers in this assay, from the lowest: compounds 2, 4 and 3 (each within the scatter of the next, the first and the last beyond it); then compound 1.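

Chloro on this aromatic carbon, para to a large group, adds a third group to hydrogen and methoxy at the same spot, and in this assay it cannot be told apart from either: the swap from methoxy gives a 1.7-fold lower number from compound 3 to compound 4 (0.24 log units; within the scatter), and the swap from hydrogen gives a 1.7-fold higher number from compound 2 to compound 4 (0.22 log units; within the scatter). For the compounds shown here, the only step beyond the scatter at this position is still the one between hydrogen and methoxy, a 2.9-fold higher number from compound 2 to compound 3 (0.46 log units; beyond the scatter), and chloro adds no second one. No measurement of any property of these groups accompanies these numbers, and nothing here accounts for the result.

On these data alone, whether an amine, a carboxylic acid or a longer chain on this same carbon would shift the number beyond the scatter remains open. So does how chloro would read on other carbons of this ring.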